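Naphthalenyl Ketone in Place of Trimethoxyphenyl in a Cytotoxicity Series

The source may report more compounds than this note shows. Statements on the series, on what has been measured and on what is new or still open speak of the compounds shown alone.

Compound 1 `COc1cc(-c2nnc3n2NC(c2ccco2)C(C(=O)c2ccco2)S3)cc(OC)c1OC`: > 100000 nM
Compound 2 `COc1cccc(C(=O)C2Sc3nnc(-c4cc(OC)c(OC)c(OC)c4)n3NC2c2ccco2)c1`: > 100000 nM
Compound 3 `COc1cc(C(=O)C2Sc3nnc(-c4cc(OC)c(OC)c(OC)c4)n3NC2c2ccco2)cc(OC)c1OC`: > 100000 nM

In a functional assay on HepG2 cells (Homo sapiens) for cytotoxicity, read by MTT assay, with a stated time of 48 h (on this read-out higher numbers stand for weaker inhibition and lower numbers for stronger inhibition), compound 1 gives only a limit, > 100000 nM. Compound 2 likewise gives only a limit, > 100000 nM. Compound 3 also stands at a limit, > 100000 nM, so its place among the three cannot be ranked; the evidence is simply (the limit of > 100000 nM in this assay, at which 3 of the 3 values shown sit). The changes on the carbonyl carbon so far, a step that the two limits leave unreadable from compound 1 to compound 3 and a step that the two limits leave unreadable from compound 2 to compound 3, are therefore unreadable in size. Compound 4 `COc1cc(-c2nnc3n2NC(c2ccco2)C(C(=O)c2cccc4ccccc24)S3)cc(OC)c1OC` carries a further change at the same place: naphthalen-1-yl in place of 3,4,5-trimethoxyphenyl on a carbonyl carbon. For the measured compounds named here, no measured step can guide the size or direction in this assay, so the expected step that the limit leaves unreadable from compound 3 to compound 4 is taken as none beyond the scatter. Compound 4 is accordingly estimated at 150000 nM, within 40000 nM to 500000 nM.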

Compound 4, half-maximal inhibitory concentration: 33900 nM
Compound 4: middle estimate off by 4.4-fold (0.65 log units), on the high side, and the stated range ends above it.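

In this assay, for the compounds shown here, naphthalen-1-yl on the carbonyl carbon gives the first readable steps at this place: an at least 2.9-fold lower number from compound 3 to compound 4 (0.46 log units; beyond the scatter) in place of 3,4,5-trimethoxyphenyl, an at least 2.9-fold lower number from compound 2 to compound 4 (0.46 log units; beyond the scatter) in place of 3-methoxyphenyl, and an at least 2.9-fold lower number from compound 1 to compound 4 (0.46 log units; beyond the scatter) in place of furan-2-yl. Going by these compounds alone, the number at this place therefore does respond to the group it carries, which the earlier compounds could not show. The steps among compound 1, compound 2 and compound 3 still cannot be read, as each of these compounds stands at a limit: the limit of > 100000 nM in this assay, at which 3 of the 4 values shown sit.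

Going by these compounds, the full size of each new step stays open, since only its lower bound can be read. Also open, on these data alone, is how naphthalen-2-yl, or an amine or a carboxylic acid on the naphthalen-1-yl group, would fare at this place.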